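The source may hold more compounds than are shown below. What is called first, only, known or untested is meant among the compounds shown, and "the series" means these compounds.

Measured compounds:
- compound 1 `O=c1cc(-c2ccccc2)oc2cc(N3COc4c(cccc4[N+](=O)[O-])C3)ccc12`: 5.65%
- compound 2 `O=c1cc(-c2ccccc2)oc2ccc(N3COc4ccccc4C3)cc12`: 68.5%
- compound 3 `O=c1cc(-c2ccccc2)oc2ccc(N3COc4c(Cl)cc(Cl)cc4C3)cc12`: 74%

All three were run in a functional assay on MCF7 cells (Homo sapiens) for inhibition, read by MTT assay, with a stated time of 48 h, tested at 30 ug/mL; on this read-out higher numbers stand for more inhibition of growth at the one concentration tested and lower numbers for less inhibition of growth. Compound 1 gives 5.65%, the lowest of the three numbers; the nearest is compound 2 with 68.5%, a gap beyond the scatter, and the furthest is compound 3 with 74%, also beyond the scatter. Compound 1 is the only one of the three that carries a nitro group; compounds 2 and 3 lack it and both sit high in this assay.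

Compound 4 `O=c1cc(-c2ccccc2)oc2cc(N3COc4ccccc4C3)ccc12` has not yet been measured. It differs from compound 1 in one place: hydrogen in place of nitro on an aromatic carbon. For the measured compounds named here, no pair of measured compounds records this exact step, so its size has to be judged from the standing of compound 1 against compounds 2 and 3. Because compound 1 gives 5.65% while the nitro-free compound 2 gives 68.5% and the nitro-free compound 3 gives 74%, removal of the nitro group is expected to move the number upward by a step well beyond the scatter, namely a number 39.4 percentage points higher from compound 1 to compound 4 (beyond the scatter). The direction is expected to be an increase, though the rest of the core is not shared with compounds 2 and 3, which leaves the size uncertain. For compound 4 the estimate in this assay is 45%, with a range from 10% to 75%.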

Compound 4, percent growth inhibition at one concentration: 12.7%
Estimate against measurement, compound 4: 32.3 percentage points above; the measured number falls inside the stated range.
By their numbers in this assay, from the lowest: compounds 1 and 4 (each within the scatter of the next); then compounds 2 and 3 (each within the scatter of the next).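

Within this assay, hydrogen in place of nitro on this aromatic carbon gives a number 7.1 percentage points higher from compound 1 to compound 4 (within the scatter), so at this place on the core of compound 1 the two substituents cannot be told apart in this read-out, and the nitro group alone does not account for the low number of compound 1. Without the nitro group, compound 4 gives 12.7%, whereas compound 2, built from the same parts joined at a different carbon, gives 68.5%, which shifts attention from the nitro group to the way those parts are joined. No measurement is at hand that gives a reason for either number.

From the compounds shown here alone, it remains open whether a chlorine, a methoxy group, an amine or a carboxylic acid on this aromatic carbon would read differently from hydrogen and nitro, or whether this place is insensitive to substitution in general. Also open, going by these compounds, is whether the same change would stay within the scatter on the core of compound 2, and whether the picture at a single concentration would hold across a full concentration range.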